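Cyclic substituent on the piperidine: sulfonamide ring for urea

A few compounds are considered here, and "the series" means these few. Any claim that something is new, unique, unknown or untested is made for them only; others in the source may bear on it.

Measured so far in a functional assay on CHO-K1 cells for antagonist activity at melanin-concentrating hormone receptor 1 (Homo sapiens), read by inositol phosphate accumulation, with stated times of 10 min and 45 min; on this read-out higher numbers stand for weaker inhibition and lower numbers for stronger inhibition:
compound 1 `Cc1nc(N2CCC(N3CCOC3=O)CC2)nc2ccc(NC(=O)/C=C/c3ccc(OC(F)(F)F)cc3)cc12`, 31 nM
compound 2 `COCC(=O)NC1CCN(c2nc(C)c3cc(NC(=O)/C=C/c4ccc(OC(F)(F)F)cc4)ccc3n2)CC1`, 14 nM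
compound 3 `Cc1nc(N2CCC(N3CCNC3=O)CC2)nc2ccc(NC(=O)/C=C/c3ccc(OC(F)(F)F)cc3)cc12`, 31 nM

Compound 3 stands level with compound 1 at the digits printed, the two together giving the highest numbers of the three; its nearest neighbour is compound 1, the furthest compound 2. Against compound 2 the step of a 2.2-fold higher number from compound 2 to compound 3 (0.35 log units; beyond the scatter) is modest, and no change at the digits printed from compound 1 to compound 3 (within the scatter) shows that exchanging the 2-oxo-1,3-oxazolidin-3-yl for the 2-oxoimidazolidin-1-yl made no difference beyond the scatter.

Compound 4 `Cc1nc(N2CCC(N3CCCS3(=O)=O)CC2)nc2ccc(NC(=O)/C=C/c3ccc(OC(F)(F)F)cc3)cc12` carries a group of 7 heavy atoms (3 carbon, 1 nitrogen, 2 oxygen, 1 sulfur; one five-membered non-aromatic ring with 2 hetero atoms) in place of a group of 6 heavy atoms (3 carbon, 2 nitrogen, 1 oxygen; one five-membered non-aromatic ring with 2 hetero atoms), on a saturated ring carbon: the ring keeps its size and its two hetero atoms, but the donor is gone and a second acceptor comes in. Going by the values given here, the steps that bear on this are no change at the digits printed from compound 1 to compound 3 (within the scatter) and a 2.2-fold lower number from compound 1 to compound 2 (0.35 log units; beyond the scatter): swapping one five-membered ring for another left the number unchanged, and only the open-chain ((methoxymethyl)carbonyl)amino moved it, modestly. Among the compounds with values here, no step shows a sulfur-containing ring at this position, so there is nothing to support a shift beyond the scatter. For compound 4 in this assay the expected step is a 1.1-fold higher number from compound 3 to compound 4 (0.05 log units; within the scatter), no more than the scatter. The estimate for compound 4 is 35 nM, range 15 nM to 85 nM.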

Compound 4, half-maximal inhibitory concentration: 16 nM
For compound 4 the middle estimate is 2.2-fold (0.34 log units) above the measured one; low and high end bracket the measured number.
By their numbers in this assay, from the lowest: compounds 2, 4, 1 and 3 (each within the scatter of the next, the first and the last beyond it).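

In this assay a sulfur-containing five-membered ring on this saturated ring carbon is tolerated, with a 1.9-fold lower number from compound 3 to compound 4 (0.29 log units; within the scatter) and a 1.9-fold lower number from compound 1 to compound 4 (0.29 log units; within the scatter), so the hydrogen-bond donor of the 2-oxoimidazolidin-1-yl is not required on this read-out. With a 1.1-fold higher number from compound 2 to compound 4 (0.06 log units; within the scatter) as well, compound 4 cannot be separated from any of the other three compounds, and it links the open-chain ((methoxymethyl)carbonyl)amino to the cyclic groups. No measurement at hand explains this tolerance.

On these data alone, whether the ring matters at all remains open, and an open-chain methanesulfonylamino group would test this directly. How far the position extends is also unsettled, as the compounds shown include no six-membered cyclic sulfonamide, free amine or carboxylic acid here.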